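This account rests on a few compounds, and the source may have more. Where it says the series, first, only, none or still open, it means among the compounds named here.

Measured compounds in a functional assay on CHO cells for agonist activity at 5-hydroxytryptamine receptor 4 (Homo sapiens), read by a luciferase reporter and cAMP accumulation, with a stated time of 4 h; a lower number here means a smaller maximal response, a higher number a larger maximal response:
compound 1 `CC(C)c1nc(C(=O)NC[C@@H]2[C@H]3CN(CC4CCC4)C[C@@H]23)c2ccccn12`, with compound 1 giving 50%
compound 2 `CC(C)c1nc(C(=O)NC[C@@H]2[C@H]3CN(C4CCC4)C[C@@H]23)c2ccccn12`, with compound 2 giving 59%
compound 3 `COC(=O)N1CCC(N2C[C@@H]3[C@@H](CNC(=O)c4nc(C(C)C)n5ccccc45)[C@@H]3C2)CC1`, with compound 3 giving 42%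

Compound 3 has the lowest of the three numbers in this assay: the two gaps are a number 8 percentage points lower from compound 1 to compound 3 (within the scatter) and a number 17 percentage points lower from compound 2 to compound 3 (beyond the scatter). Compound 4 `COCC(C)(C)CN1C[C@@H]2[C@@H](CNC(=O)c3nc(C(C)C)n4ccccc34)[C@@H]2C1` differs from compound 3 by 2-(methoxymethyl)-2-methylpropyl in place of 1-(methoxycarbonyl)piperidin-4-yl on an amine nitrogen in a ring. Among the compounds with values here, the steps that bear on this change are those that alter the same position: a number 9 percentage points higher from compound 1 to compound 2 (within the scatter) and a number 8 percentage points lower from compound 1 to compound 3 (within the scatter), both within the scatter, and a number 17 percentage points lower from compound 2 to compound 3 (beyond the scatter), a modest step beyond it. Compound 4 carries an acyclic chain at that position, as compound 1 does, so the expected step from compound 3 is small, a number 8 percentage points higher from compound 3 to compound 4 (within the scatter), probably within the scatter. The value expected for compound 4 in this assay is 50%, with a range from 38% to 62%.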

Compound 4, largest response reached (Emax), in percent of the reference or control that the assay uses: 53%
Compound 4: the middle estimate sits 3 percentage points below what was measured; the range from low to high includes it.
By their numbers in this assay, from the lowest: compounds 3, 1, 4 and 2 (each within the scatter of the next, the first and the last beyond it).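

In this assay the step of a number 11 percentage points higher from compound 3 to compound 4 (beyond the scatter) is modest but beyond the scatter, so 1-(methoxycarbonyl)piperidin-4-yl now sits apart from an acyclic 2-(methoxymethyl)-2-methylpropyl group as well as from cyclobutyl. The steps of a number 6 percentage points lower from compound 2 to compound 4 (within the scatter) and a number 3 percentage points higher from compound 1 to compound 4 (within the scatter) stay within the scatter, so this chain cannot be told apart from cyclobutyl or cyclobutylmethyl at this amine nitrogen. No measurement here explains these differences.

Still open, going by these compounds, is how a carboxylic acid, an unsubstituted piperidine or a longer alkyl chain on this nitrogen would read, and whether any group there takes the maximal response outside the range seen so far.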